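The compounds below may be only part of what the source reports. "The series", "measured", "known", "first", "only" and "open" are said of these compounds alone.

Measured in a physicochemical assay for metabolic stability, read by HPLC, in simulated gastric fluid, at pH 1.2, tested at 100 uM (on this read-out higher numbers stand for a longer-lived compound and lower numbers for a shorter-lived compound), so far:
- compound 1 `C[C@@H](O)[C@H]1C(=O)N2C(C(=O)OCOC(=O)OC3CCCc4ccccc4C3)=C(S[C@@H]3CN[C@H](C(=O)N(C)C)C3)[C@H](C)[C@H]12` with 0.35 h
- compound 2 `CC(OC(=O)O[C@H]1CCCCc2ccccc21)OC(=O)C1=C(S[C@@H]2CN[C@H](C(=O)N(C)C)C2)[C@H](C)[C@@H]2[C@@H]([C@@H](C)O)C(=O)N12` with 0.3 h

Among the measured compounds shown here, compound 1 at 0.35 h and compound 2 at 0.3 h lie within the usual scatter of each other, so compound 1 stands level with the only other number available. Compound 3 `C[C@@H](O)[C@H]1C(=O)N2C(C(=O)OCOC(=O)O[C@@H]3CCCCc4ccccc43)=C(S[C@@H]3CN[C@H](C(=O)N(C)C)C3)[C@H](C)[C@H]12` keeps the core of compound 1 and differs in one group, where the same atoms are joined differently: a group of 11 heavy atoms (11 carbon; one six-membered aromatic ring of carbon only, one seven-membered non-aromatic ring of carbon only) in place of a group of 11 heavy atoms (11 carbon; one six-membered aromatic ring of carbon only, one seven-membered non-aromatic ring of carbon only), on an oxygen next to a carbonyl group is the whole change. The entering group also has a defined stereocentre. For the measured compounds named here, no measured pair isolates this change, so the evidence is thin. In this assay no step beyond the scatter is expected, and the estimated 1.1-fold lower number from compound 1 to compound 3 (0.04 log units; within the scatter) points in no firm direction. Compound 3 is expected to give 0.32 h (estimated range 0.18 h to 0.55 h) when it is measured.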

Compound 3, half-life: 0.183 h
The estimate for compound 3 lay 1.7-fold (0.24 log units) above the measured number; low and high end bracket the measured number.
By their numbers in this assay, from the lowest: compounds 3, 2 and 1 (each within the scatter of the next).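

Among the compounds shown here, compound 1 and compound 3 form the first pair that isolates a change on an oxygen next to a carbonyl group, and in this assay the step is a 1.9-fold lower number from compound 1 to compound 3 (0.28 log units; within the scatter) and stays inside the usual scatter. Rejoining the same carbon atoms, with the six-membered aromatic ring and seven-membered non-aromatic ring both kept and one defined stereocentre added in the entering group, therefore gives no firm difference in half-life at this position. The compounds shown offer no independent evidence that could explain the numbers.

From the compounds shown here alone, it remains open whether the opposite configuration at that stereocentre would read the same. Going by these compounds, it is also open whether a simpler group on the same oxygen, such as cyclohexyl or ethyl, would remain level with compound 1.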